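Quinolin-3-yl for Phenyl and Tolerance in Human Cells

The source may report more compounds than this note shows. Statements on the series, on what has been measured and on what is new or still open speak of the compounds shown alone.

Compound 1 `CC(C)CCc1sc(NC(=O)c2cc(NC(=O)c3cc(NC(=N)c4cnc5ccccc5c4)cn3C)cn2C)nc1C(=O)NCCCN(C)C` gives 1.2 ug/mL in an ADME assay on HEK293 cells (Homo sapiens) for cytotoxicity, read by fluorescence and resazurin assay, with a stated time of 20 h; a lower number here means that less compound is tolerated, a higher number that more compound is tolerated. Compound 2 `CC(C)CCc1sc(NC(=O)c2cc(NC(=O)c3cc(NC(=N)c4ccccc4)cn3C)cn2C)nc1C(=O)NCCCN(C)C` gives only a limit in this assay, > 32 ug/mL. For compound 3 `CN(C)CCCNC(=O)c1cc(NC(=O)c2cc(NC(=O)c3cc(NC(=N)c4ccccc4)cn3C)cn2C)cn1C` the entry in this assay reads "not determined" (no result reported), so no number is available for it.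

Within the measured pair, the change quinolin-3-yl in place of phenyl on a carbon with a double bond to nitrogen produced an at least 26-fold lower number from compound 2 to compound 1 (1.42 log units; beyond the scatter). The cores of compound 2 and compound 3 differ, but that difference is not broken down here. Compound 4 `CN(C)CCCNC(=O)c1cc(NC(=O)c2cc(NC(=O)c3cc(NC(=N)c4cnc5ccccc5c4)cn3C)cn2C)cn1C` carries the same change relative to compound 3, namely (quinolin-3-yl in place of phenyl on a carbon with a double bond to nitrogen), at the same kind of place. With no number for compound 3, the expectation for compound 4 rests on the earlier step, because an at least 26-fold lower number from compound 2 to compound 1 (1.42 log units; beyond the scatter) shows the quinolin-3-yl partner lowering the number strongly. Compound 4 is therefore expected to give about 4 ug/mL, estimated between 1 ug/mL and 20 ug/mL, in this assay.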

Compound 4, half-maximal cytotoxic concentration: > 32 ug/mL
Compound 4 gave a limit, no number; the forecaster's own chance of this, stated with the estimate: 25%; middle value at least 8.0-fold (0.90 log units) away from the limit.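

Compound 3 has no number in this assay and compound 4 has only a limit, and no step can be read between them. From the compounds shown here alone, whether quinolin-3-yl in place of phenyl lowers the number on the core of compound 3, as it does on the core of compound 2, stays open.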